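Trimethoxyphenyl for fluoromethoxyphenyl on the methyl-bearing analogue

The source may hold more compounds than are shown below. What is called first, only, known or untested is meant among the compounds shown, and "the series" means these compounds.

The series shares one core and varies the aryl ketone and a ring substituent. In a functional assay on MDA-MB-231 cells (Homo sapiens) for antiproliferative activity, read by sulforhodamine B assay, with a stated time of 48 h (on this read-out lower numbers stand for stronger inhibition and higher numbers for weaker inhibition), compound 1 `COc1cc(OC)c2sc(-c3ccc(N/C=C\C(=O)c4cc(OC)c(OC)c(OC)c4)cc3)nc2c1` gives 15800 nM, compound 2 `COc1cc(OC)c2sc(-c3ccc(N/C=C\C(=O)c4ccc(OC)c(F)c4)c(C)c3)nc2c1` gives 13300 nM, and compound 3 `COc1cc(OC)c2sc(-c3ccc(N/C=C\C(=O)c4ccc(OC)c(F)c4)cc3)nc2c1` gives 6700 nM. Compound 2 thus sits second highest of the three numbers, close to compound 1 and furthest from compound 3; the step of a 2.0-fold lower number from compound 2 to compound 3 (0.30 log units; within the scatter) and the gap to compound 1 both stay within the scatter, so no ranking among them is warranted.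

Compound 4 `COc1cc(OC)c2sc(-c3ccc(N/C=C\C(=O)c4cc(OC)c(OC)c(OC)c4)c(C)c3)nc2c1` is not yet measured. It differs from compound 2 in one place: 3,4,5-trimethoxyphenyl in place of 3-fluoro-4-methoxyphenyl on a carbonyl carbon. The same exchange, run in the opposite direction without the methyl group, is covered by a 2.4-fold lower number from compound 1 to compound 3 (0.37 log units; beyond the scatter), a modest shift that just exceeds the scatter. Reversing that step on compound 2 is expected to raise the number in this assay by a similar modest amount, giving a 2.4-fold higher number from compound 2 to compound 4 (0.38 log units; beyond the scatter). Compound 4 is therefore estimated at 32000 nM, with a range of 15000 nM to 70000 nM.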

Compound 4, half-maximal inhibitory concentration: 13800 nM
Compound 4: the middle estimate sits 2.3-fold (0.37 log units) above what was measured; the measured number lies below the stated range.
By their numbers in this assay, from the lowest: compounds 3, 2, 4 and 1 (each within the scatter of the next, the first and the last beyond it).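

In this assay, the exchange on the carbonyl carbon gives no separable shift on the methyl-bearing core, a 1.0-fold higher number from compound 2 to compound 4 (0.02 log units; within the scatter), and methyl on the aromatic carbon gives none with 3,4,5-trimethoxyphenyl in place, a 1.1-fold lower number from compound 1 to compound 4 (0.06 log units; within the scatter). The aryl exchange therefore reads differently on the two cores, but that difference does not establish a dependence on the core: the same change on two cores in this assay, a 2.4-fold lower number (0.37 log units; beyond the scatter) from compound 1 to compound 3 and a 1.0-fold lower number (0.02 log units; within the scatter) from compound 4 to compound 2, 2.3-fold (0.36 log units) apart, within the scatter of two such steps. The methyl change likewise gives no firm sign of depending on the aryl group: the same change on two cores in this assay, a 2.0-fold lower number (0.30 log units; within the scatter) from compound 2 to compound 3 and a 1.1-fold higher number (0.06 log units; within the scatter) from compound 4 to compound 1, 2.3-fold (0.36 log units) apart, within the scatter of two such steps.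

On these data alone, whether either change truly depends on the other remains open, as does the size of any such dependence. As far as these compounds go, it is also open whether an amine or a carboxylic acid on the aryl ketone, or a longer chain in place of the methyl, would move the number beyond the scatter on either core.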